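Trifluoromethyl on the pendant phenyl: expected cytotoxicity

This account rests on a few compounds, and the source may have more. Where it says the series, first, only, none or still open, it means among the compounds named here.

The series shares one core; compound 1 `CCN(CC)Cc1cc(-c2ccccc2)n(Nc2ccnc3cc(Cl)ccc23)c1C` carries a diethylamino group and an unsubstituted phenyl. In an ADME assay on HMEC-1 cells (Homo sapiens) for cytotoxicity, read by MTT assay, with a stated time of 72 h (on this read-out lower numbers stand for higher toxicity in this test and higher numbers for lower toxicity in this test), compound 1 gives 16700 nM. Compound 2 `Cc1c(CN2CCCC2)cc(-c2ccccc2)n1Nc1ccnc2cc(Cl)ccc12` has the pyrrolidin-1-yl group instead, and in this assay compound 2 gives 12900 nM; the change is a 1.3-fold lower number from compound 1 to compound 2 (0.11 log units; within the scatter). Compound 3 `CCN(CC)Cc1cc(-c2ccc(F)cc2)n(Nc2ccnc3cc(Cl)ccc23)c1C` keeps the diethylamino group with fluoro on the phenyl, and in this assay compound 3 gives 18600 nM; that change is a 1.1-fold higher number from compound 1 to compound 3 (0.05 log units; within the scatter). Compound 2 thus stands with the other two inside the scatter, and compound 2 and compound 3 differ by less than the scatter.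

Compound 4 `Cc1c(CN2CCCC2)cc(-c2ccc(C(F)(F)F)cc2)n1Nc1ccnc2cc(Cl)ccc12` differs from compound 2 by trifluoromethyl in place of hydrogen on an aromatic carbon, on an aromatic carbon of a six-membered aromatic ring of carbon only, para to a large group; read one bond further out, phenyl becomes 4-(trifluoromethyl)phenyl. For the measured compounds named here, the only step on that ring is the fluoro step, and it stayed inside the scatter. No step beyond the scatter is therefore expected in this assay for compound 4, and the expected step is a 1.0-fold higher number from compound 2 to compound 4 (0.00 log units; within the scatter). Compound 4 is estimated at 13000 nM, with a range of 6000 nM to 30000 nM.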

Compound 4, half-maximal cytotoxic concentration: 4700 nM
Compound 4: the middle estimate sits 2.8-fold (0.44 log units) above what was measured, outside the stated range (below it).
By their numbers in this assay, from the lowest: compound 4; then compounds 2, 1 and 3 (each within the scatter of the next).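

In this assay, for the compounds shown here, this place on the pendant phenyl proves able to move the number: a 2.7-fold lower number from compound 2 to compound 4 (0.44 log units; beyond the scatter) is the first step beyond the scatter, and it goes toward higher toxicity in this test. The fluoro step on the same carbon, a 1.1-fold higher number from compound 1 to compound 3 (0.05 log units; within the scatter) stayed within the scatter, so at this place the outcome depends on which group enters, although that step was read with the diethylamino group and the new one with the pyrrolidin-1-yl group. Nothing at hand explains the size of the new step.

On these data alone, whether trifluoromethyl gives a similar step when the diethylamino group replaces the pyrrolidin-1-yl group remains open. So does where chloro, methoxy or nitrile on this same carbon would fall relative to hydrogen and trifluoromethyl.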